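Chain extension and whole-animal potency in the series

The source may report more compounds than this note shows. Statements on the series, on what has been measured and on what is new or still open speak of the compounds shown alone.

Measured so far:
Compound 1 `CCCCCCc1cccc(N2CCNCC2)n1` gives > 100 mg/kg in a functional assay on the whole organism with Mus musculus as the target; on this read-out higher numbers stand for an effect only at larger amounts of compound and lower numbers for an effect already at smaller amounts; this value is a limit of the assay, not a number.
Compound 2 `CCCCCCCc1cccc(N2CCNCC2)n1` gives 21 mg/kg in this assay.

Within the data shown here, compound 2 holds the only actual number in this assay; the other value shown is a limit. The change to compound 3 `CCCCCCCCCc1cccc(N2CCNCC2)n1` is ethyl in place of hydrogen on a saturated chain carbon, seven bonds along the chain from an aromatic carbon, a further lengthening of the same chain. Among the measured compounds shown here, the one measured step that bears on it, an at least 4.7-fold lower number from compound 1 to compound 2 (0.67 log units; beyond the scatter), also lengthened this chain and lowered the dose, though its size rests on the limit of > 100 mg/kg in this assay, at which 1 of the 2 values shown sits, and is only a lower bound. Whether a further extension continues in the same direction cannot be settled from two points. A modest further fall in dose is therefore expected for compound 3, estimated at 12 mg/kg with a range of 4 mg/kg to 40 mg/kg. The expected step of a 1.8-fold lower number from compound 2 to compound 3 (0.24 log units; within the scatter) is taken to lie near the edge of the scatter.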

Compound 3, dose for half-maximal effect: > 100 mg/kg
Compound 3: only a limit was reported; the forecaster's own chance of this, stated with the estimate: 10%; middle value at least 8.3-fold (0.92 log units) from the limit.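

In this assay, lengthening this chain does not keep moving the dose in one direction: the further extension gives an at least 4.7-fold higher number from compound 2 to compound 3 (0.67 log units; beyond the scatter), the reverse of the direction in an at least 4.7-fold lower number from compound 1 to compound 2 (0.67 log units; beyond the scatter). Among these three compounds, only compound 2 gives an actual number, with a shorter chain in compound 1 and a longer chain in compound 3, and both readable steps are lower bounds only: the limit of > 100 mg/kg in this assay, at which 2 of the 3 values shown sit. The step between compound 1 and compound 3 cannot be read, as both values are limits.

On these data alone, how far compound 1 and compound 3 lie past the limit remains open, so the true height of the two steps is unknown. Also open, as far as these compounds go, is where an octyl chain would fall, and whether an amine or a hydroxyl group on the chain would change the picture.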